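The compounds below may be only part of what the source reports. "The series", "measured", "known", "first", "only" and "open" are said of these compounds alone.

Compound 1, `C[C@H](NC(=O)C(=O)Nc1cccnc1N(C)C)C(=O)N[C@@H](CC(=O)O)C(=O)COc1c(F)c(F)cc(F)c1F`, gives 27 nM in a functional assay on Jurkat cells (Homo sapiens); a higher number here means a weaker inhibitor, a lower number a stronger inhibitor.
Compound 2, `Cc1ccccc1CNC(=O)C(=O)N[C@@H](C)C(=O)N[C@@H](CC(=O)O)C(=O)COc1c(F)c(F)cc(F)c1F`, gives 52 nM in this assay.
Compound 3, `Cc1ccc(CNC(=O)C(=O)N[C@@H](C)C(=O)N[C@@H](CC(=O)O)C(=O)COc2c(F)c(F)cc(F)c2F)c(C)c1`, gives only the limit > 10000 nM in this assay, so no number is known for it.

Compound 1 holds the lowest of the two numbers shown; compound 2 lies nearest to it, with a 1.9-fold higher number from compound 1 to compound 2 (0.28 log units; within the scatter), and the third value is a limit (the limit of > 10000 nM in this assay, at which 1 of the 3 values shown sits).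

Compound 4, `C[C@H](NC(=O)C(=O)NCc1cccc(Cl)c1Cl)C(=O)N[C@@H](CC(=O)O)C(=O)COc1c(F)c(F)cc(F)c1F`, differs from compound 1 in one place: 2,3-dichlorobenzyl in place of 2-(dimethylamino)pyridin-3-yl on an amide-type nitrogen.

Going by the values given here, three measured steps bear on this change. The step of a 1.9-fold higher number from compound 1 to compound 2 (0.28 log units; within the scatter) shows that a 2-methylbenzyl on the same nitrogen is carried almost unchanged. The step of an at least 370-fold higher number from compound 1 to compound 3 (2.56 log units; beyond the scatter) and the step of an at least 190-fold higher number from compound 2 to compound 3 (2.28 log units; beyond the scatter) show that a 2,4-dimethylbenzyl is not carried, and that the difference of a single methyl on an aromatic carbon decides it. A 2,3-dichlorobenzyl is a substituted benzyl of a kind not yet measured, so the outcome is uncertain; the expected step is a 4.4-fold higher number from compound 1 to compound 4 (0.65 log units; beyond the scatter), a loss in this assay, but short of the limit. Compound 4 is therefore estimated at 120 nM, between 20 nM and 2500 nM.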

Compound 4, half-maximal inhibitory concentration: 76 nM
Beside the measured number, compound 4's estimate is 1.6-fold (0.20 log units) above it, and the stated range covers the measured number.
By their numbers in this assay, from the lowest: compounds 1, 2 and 4 (each within the scatter of the next, the first and the last beyond it). At a limit, above all of these: compound 3.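

The 2,3-dichlorobenzyl group is carried on the amide-type nitrogen in this assay about as well as 2-methylbenzyl, with a 1.5-fold higher number from compound 2 to compound 4 (0.16 log units; within the scatter), so two substituents on the benzyl ring do not in themselves end activity. Replacing the 2-(dimethylamino)pyridin-3-yl group does have a modest cost here, a 2.8-fold higher number from compound 1 to compound 4 (0.45 log units; beyond the scatter), which the step to 2-methylbenzyl did not show, since that step stayed within the scatter. The third step, an at least 130-fold lower number from compound 3 to compound 4 (2.11 log units; beyond the scatter), starts from a limit and is a bound only, and it ties the loss to the 2,4-dimethylbenzyl group, not to benzyl groups with two substituents in general: the limit of > 10000 nM in this assay, at which 1 of the 4 values shown sits.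

Whether a 2,4-dichlorobenzyl or a 2,3-dimethylbenzyl would fall with compound 3 or stand with compound 4 remains open, so the compounds shown do not separate the pattern of substitution from the kind of substituent. Also open, on these data alone, is how an unsubstituted benzyl or a pyridin-3-ylmethyl group on the same nitrogen would compare with compound 1.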